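The compounds below may be only part of what the source reports. "The series", "measured", "known", "first", "only" and "open" are said of these compounds alone.

Compounds measured in a functional assay on HEK293 cells for antagonist activity at G-protein coupled receptor 52 (Homo sapiens), read by cAMP accumulation, with stated times of 15 min and 30 min; a lower number here means a stronger inhibitor, a higher number a weaker inhibitor:
compound 1 `O=C(/C=C/CCc1ccccc1)N1CCCCC1`: "not active" (no number reported)
compound 2 `Cc1cccc(C)c1C(=O)/C=C/CCc1ccccc1`: 2820 nM

Compound 1 stands without a number in this assay; it is recorded only as "not active" (no number reported). Compound 2 gives 2820 nM in this assay. Compound 3 `O=C(/C=C/CCc1ccccc1)c1ccccn1` arises from compound 1 by pyridin-2-yl in place of piperidin-1-yl on a carbonyl carbon. Going by the values given here, no measured pair shows this change, so the size of the step is unknown; the author expects compound 3 to be stronger than compound 1, since compound 2, the other carbonyl compound without the piperidine, is the one that gives a number. Compound 3 is estimated at 6000 nM, within 1200 nM to 30000 nM.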

Compound 3, half-maximal inhibitory concentration: 1820 nM
Beside the measured number, compound 3's estimate is 3.3-fold (0.52 log units) above it, and the stated range covers the measured number.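

Compound 1 has no number in this assay, and the step from it to compound 3 cannot be read. Going by these compounds, the size of the change from piperidin-1-yl to pyridin-2-yl stays open. No measurement shown accounts for the result.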